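Swapping ethyl for difluorophenyl on the amide of compound 3

The source may hold more compounds than are shown below. What is called first, only, known or untested is meant among the compounds shown, and "the series" means these compounds.

Compound 3 `CCNC(=O)c1cnc(N2CCN(C3CCN(Cc4ccc(Cl)cc4)CC3)[C@@H](C)C2)c(Cl)c1` stands lowest of the three measured compounds in a functional assay for antagonist activity at C-X-C chemokine receptor type 3 (Homo sapiens) (a higher number here means a weaker inhibitor, a lower number a stronger inhibitor), with 2.3 nM. Compound 1 `C[C@H]1CN(c2ncc(C(=O)NCc3ccc(F)c(F)c3)cc2Cl)CCN1C1CCN(Cc2ccc(Cl)cc2)CC1` gives 6 nM, and compound 2 `C[C@H]1CN(c2ncc(NC(=O)C3CC3)cc2Cl)CCN1C1CCN(Cc2ccc(Cl)cc2)CC1` gives 20 nM; the step of an 8.7-fold lower number from compound 2 to compound 3 (0.94 log units; beyond the scatter) is the wider gap, while a 2.6-fold lower number from compound 1 to compound 3 (0.42 log units; beyond the scatter) is the nearer one. Among the compounds with values here, that nearer step, which exchanges a 3,4-difluorophenyl group for a small alkyl group, is the one that bears on compound 4 `C[C@H]1CN(c2ncc(C(=O)Nc3ccc(F)c(F)c3)cc2Cl)CCN1C1CCN(Cc2ccc(Cl)cc2)CC1`, whose change from compound 3 is 3,4-difluorophenyl in place of ethyl on an amide-type nitrogen. Putting an aromatic ring back onto the amide is expected to undo part of that gain, so a modest rise in this assay is expected: a 3.0-fold higher number from compound 3 to compound 4 (0.48 log units; beyond the scatter). Compound 4 is therefore estimated at 7 nM, within a range of 2.5 nM to 20 nM.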

Compound 4, half-maximal inhibitory concentration: 22 nM
Compound 4: middle estimate off by 3.1-fold (0.50 log units), on the low side; the measured number lies above the stated range.
By their numbers in this assay, from the lowest: compound 3; then compound 1; then compounds 2 and 4 (each within the scatter of the next).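

On the amide-type nitrogen, a directly attached aromatic ring costs far more than the small alkyl group does, with a 9.6-fold higher number from compound 3 to compound 4 (0.98 log units; beyond the scatter) in this assay. The ring's attachment also matters, since 3,4-difluorophenyl in place of 3,4-difluorobenzyl gives a 3.7-fold higher number from compound 1 to compound 4 (0.56 log units; beyond the scatter), while the change of amide group in a 1.1-fold higher number from compound 2 to compound 4 (0.04 log units; within the scatter) leaves the two compounds level. Nothing available explains these differences.

Whether the ring itself or its two fluorines account for the rise remains open. Plain phenyl or cyclohexyl on this nitrogen would separate those two possibilities.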